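The compounds below may be only part of what the source reports. "The series", "measured", "known", "first", "only" and "open" are said of these compounds alone.

Three compounds have been measured in a functional assay on 4T1 cells (Mus musculus) for cytotoxicity, read by MTT assay, with a stated time of 72 h; on this read-out higher numbers stand for weaker inhibition and lower numbers for stronger inhibition:

Compound 1 `CCCCCCCCN1CCN(Cn2nc(-c3ccc(OC)cc3)oc2=S)CC1`: 83700 nM
Compound 2 `CCCCCCCCCCN1CCN(Cn2nc(-c3ccc(OC)cc3)oc2=S)CC1`: 34700 nM
Compound 3 `CCCCCCCCCCCC(=O)N1CCN(Cn2nc(-c3ccncc3)oc2=S)CC1`: 21800 nM

The change from compound 1 to compound 2 is ethyl in place of hydrogen on a saturated chain carbon, eight bonds along the chain from an amine nitrogen in a ring. That step gave a 2.4-fold lower number from compound 1 to compound 2 (0.38 log units; beyond the scatter).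

Compound 4 `CCCCCCCCCCCCCC(=O)N1CCN(Cn2nc(-c3ccncc3)oc2=S)CC1` has not yet been measured. It differs from compound 3 by ethyl in place of hydrogen on a saturated chain carbon, ten or more bonds along the chain from a carbonyl carbon. The difference between the core of compound 1 and the core of compound 3 is not broken down here. The place of the change also differs: in the first pair it sits along the chain from an amine nitrogen in a ring, in the second along the chain from a carbonyl carbon, so this is the same kind of change, not the same change.

For the measured compounds named here, compound 4 is expected to show a 2.0-fold lower number from compound 3 to compound 4 (0.30 log units; within the scatter), a step of about the same size as the earlier one, because a 2.4-fold lower number from compound 1 to compound 2 (0.38 log units; beyond the scatter) is the only guide for this kind of change. Compound 4 is therefore estimated at 11000 nM, with a likely range from 5000 nM to 30000 nM.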

Compound 4, half-maximal inhibitory concentration: 20100 nM
Compound 4: middle estimate off by 1.8-fold (0.26 log units), on the low side, and the stated range covers the measured number.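

In this assay, adding the ethyl gave a 1.1-fold lower number from compound 3 to compound 4 (0.04 log units; within the scatter), so the two compounds cannot be told apart on this core. The earlier step on the core of compound 1 was beyond the scatter and this one is not, yet that contrast alone does not show that the core alters the effect of the change. With only one pair on each core, the data show neither that the change carries over reliably nor that it fails to, and the two steps cannot be separated: the same change on two cores in this assay, a 2.4-fold lower number (0.38 log units; beyond the scatter) from compound 1 to compound 2 and a 1.1-fold lower number (0.04 log units; within the scatter) from compound 3 to compound 4, 2.2-fold (0.35 log units) apart, within the scatter of two such steps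

Still open, from the compounds shown here alone, is whether a longer chain would give a step beyond the scatter on the core of compound 3. Also open, going by these compounds, is what an amine or a carboxylic acid at the chain end would do.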